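Aryl thiourea variant in the shared core series

The source may report more compounds than this note shows. Statements on the series, on what has been measured and on what is new or still open speak of the compounds shown alone.

Measured so far in a functional assay on HL-60 cells (Homo sapiens) for antiproliferative activity, with a stated time of 24 h; on this read-out higher numbers stand for weaker inhibition and lower numbers for stronger inhibition:
compound 1, `Cc1ccccc1CN1CCc2c(sc(NC(=O)c3ccccc3Cl)c2C(N)=O)C1`, gives > 50000 nM, which is a limit of the assay (the limit of > 50000 nM in this assay, at which 1 of the 3 values shown sits).
compound 2, `NC(=O)c1c(NC(=O)c2ccccc2Cl)sc2c1CCN(Cc1c(Cl)cccc1Cl)C2`, gives 4850 nM.
compound 3, `CSc1ccccc1NC(=S)N1CCc2c(sc(NC(=O)c3ccccc3Cl)c2C(N)=O)C1`, gives 14600 nM.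

Compound 3 holds the higher of the two numbers, with compound 2 nearest: a 3.0-fold higher number from compound 2 to compound 3 (0.48 log units; beyond the scatter). The other steps, an at least 10-fold lower number from compound 1 to compound 2 (1.01 log units; beyond the scatter) and an at least 3.4-fold lower number from compound 1 to compound 3 (0.53 log units; beyond the scatter), also change only the group on the amine nitrogen in the ring. Going by the values given here, compound 4, `NC(=O)c1c(NC(=O)c2ccccc2Cl)sc2c1CCN(C(=S)Nc1cccnc1)C2`, instead differs by pyridin-3-yl in place of 2-(methylsulfanyl)phenyl on an amide-type nitrogen; no measured step touches this position, so the expected change is a 1.2-fold higher number from compound 3 to compound 4 (0.09 log units; within the scatter), within the scatter. Compound 4 is therefore estimated at 18000 nM, likely between 6000 nM and 55000 nM.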

Compound 4, half-maximal inhibitory concentration: 33900 nM
The estimate for compound 4 lay 1.9-fold (0.27 log units) below the measured number, and the stated range covers the measured number.
By their numbers in this assay, from the lowest: compound 2; then compound 3; then compound 4. At a limit, above all of these: compound 1.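

On the thiourea, pyridin-3-yl in place of 2-(methylsulfanyl)phenyl on the amide-type nitrogen gives a 2.3-fold higher number from compound 3 to compound 4 (0.37 log units; beyond the scatter) in this assay, the first read of this position. The gap to the 2,6-dichlorophenyl compound widens as well (a 7.0-fold higher number from compound 2 to compound 4 (0.84 log units; beyond the scatter)), so the number in this series moves with the group on that nitrogen, not only with the group on the ring amine. Compound 1 stands at a limit: the limit of > 50000 nM in this assay, at which 1 of the 4 values shown sits. The step, an at least 1.4-fold lower number from compound 1 to compound 4 (0.16 log units; that floor lies within the scatter), is a floor only and cannot be read.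

The step to pyridin-3-yl swaps the ring nitrogen and the methylsulfanyl group together, and the compounds shown do not separate the two. A plain phenyl group on the same nitrogen would tell them apart.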